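Swapping the sulfonamide ring: an estimate for compound 3

The compounds below may be only part of what the source reports. "The series", "measured", "known", "first", "only" and "open" are said of these compounds alone.

Measured so far in a physicochemical assay for lipophilicity; on this read-out lower numbers stand for lower lipophilicity and higher numbers for higher lipophilicity
compound 1 (`Cc1nc(-c2cc(C(F)(F)F)ccc2[C@H]2CCOc3cc(S(=O)(=O)Nc4ccncn4)ccc32)co1`) gives ("not determined" (no result reported))
compound 2 (`O=S(=O)(Nc1ncccn1)c1ccc2c(c1)OCC[C@@H]2c1ccc(C(F)(F)F)cc1-c1ccc(F)nc1`) gives (2.8)

Compound 1 is the starting point here, yet it offers no number to start from, since compound 1 stands at ("not determined" (no result reported)). Among the measured compounds shown here, the only measured number available comes from compound 2 (2.8). Compound 3 (`Cc1nc(-c2cc(C(F)(F)F)ccc2[C@H]2CCOc3cc(S(=O)(=O)Nc4cccc(F)n4)ccc32)co1`) keeps the core of compound 1 and carries 6-fluoropyridin-2-yl in place of pyrimidin-4-yl on a sulfonamide nitrogen. For the measured compounds named here, no measured pair shows this swap, so the data cannot give its size. A modest rise in this assay is expected, close to the edge of the usual scatter, and this is a judgement rather than a measurement. Compound 3 is expected at (3.2), with an estimated range of (2.7 to 3.8).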

Compound 3, distribution coefficient: 4
Estimate against measurement, compound 3: 0.80 log units below; measured number outside the range, above it.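

In this assay compound 1 gives ("not determined" (no result reported)) and compound 3 gives (4), so no step can be read between them. As far as these compounds go, how far 6-fluoropyridin-2-yl in place of pyrimidin-4-yl moves this read-out on its own stays open. Nothing shown offers an explanation for the value of compound 3.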